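Thioether ketone series: methoxy step from compound 3 to compound 4

This account rests on a few compounds, and the source may have more. Where it says the series, first, only, none or still open, it means among the compounds named here.

Compound 1 `COc1ccc(-c2nc(C)c(C(=O)CSc3nc(-c4cccc(OC)c4)c(C#N)c(=O)[nH]3)s2)cc1`: 12.4%
Compound 2 `COc1cccc(-c2nc(SCC(=O)c3sc(-c4ccccc4)nc3C)[nH]c(=O)c2C#N)c1`: 21.8%
Compound 3 `Cc1nc(-c2ccccc2)sc1C(=O)CSc1nc(-c2ccc(Cl)c(Cl)c2)c(C#N)c(=O)[nH]1`: 24.4%

In a functional assay on U-87MG ATCC cells for antiproliferative activity against U-87 MG (Homo sapiens), read by MTT assay, with a stated time of 48 h, tested at 100 uM (a higher number here means a weaker effect of the compound at the concentration tested, a lower number a stronger effect), the three measured compounds share one thioether-linked ketone scaffold and differ at two sites. The cores of compound 2 and compound 3 differ by 3,4-dichlorophenyl in place of 3-methoxyphenyl on an aromatic carbon, and the step this made is a number 2.6 percentage points higher from compound 2 to compound 3 (within the scatter). Among the measured compounds shown here, the value of compound 1 lies below that of compound 3 by more than the scatter, but no single-site step connects them.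

One change occurs twice. From compound 2 to compound 1 it is methoxy in place of hydrogen on an aromatic carbon, with a step of a number 9.4 percentage points lower from compound 2 to compound 1 (within the scatter). Compound 4 `COc1ccc(-c2nc(C)c(C(=O)CSc3nc(-c4ccc(Cl)c(Cl)c4)c(C#N)c(=O)[nH]3)s2)cc1` arises from compound 3 by methoxy in place of hydrogen on an aromatic carbon, the same change at the same place.

The step is expected to be a number 8.4 percentage points lower from compound 3 to compound 4 (within the scatter) because the earlier instance gave a number 9.4 percentage points lower from compound 2 to compound 1 (within the scatter). Compound 4 is therefore estimated at 16%, between 6% and 28%.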

Compound 4, a percentage reported as activity, at one concentration (the size of the read-out at that concentration, not a potency): 31.1%
For compound 4 the middle estimate is 15.1 percentage points below the measured one; measured number above the stated range.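

Methoxy in place of hydrogen gives a number 6.7 percentage points higher from compound 3 to compound 4 (within the scatter) in this assay, and this step does not match the one on the other core: the same change on two cores in this assay, a number 9.4 percentage points lower (within the scatter) from compound 2 to compound 1 and a number 6.7 percentage points higher (within the scatter) from compound 3 to compound 4, 16.1 percentage points apart, beyond the scatter of two such steps. The exchange of 3-methoxyphenyl for 3,4-dichlorophenyl gives a number 18.7 percentage points higher from compound 1 to compound 4 (beyond the scatter), which likewise differs from its earlier instance: the same change on two cores in this assay, a number 2.6 percentage points higher (within the scatter) from compound 2 to compound 3 and a number 18.7 percentage points higher (beyond the scatter) from compound 1 to compound 4, 16.1 percentage points apart, beyond the scatter of two such steps. Both gaps rest on the same four compounds, so they show that the two changes do not act independently here, but not how either would behave on any further core.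

From the compounds shown here alone, an amine or a carboxylic acid at the place of the methoxy remains open. So does whether these differences in the size of the effect at one concentration would hold at other concentrations.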